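A few compounds are considered here, and "the series" means these few. Any claim that something is new, unique, unknown or untested is made for them only; others in the source may bear on it.

In a functional assay on L1210 cells (Mus musculus) for inhibition (on this read-out higher numbers stand for weaker inhibition and lower numbers for stronger inhibition), compound 1 `O=C1CCCCC/C1=C\c1ccc(F)cc1` gives 291000 nM and compound 2 `O=C1CCCCC/C1=C\c1ccc(Br)cc1` gives 68400 nM on the same core. Compound 3 `Cc1ccc(/C=C2\CCCCCC2=O)cc1` reads > 500000 nM as a limit of the assay and not a number. Compound 4 `CN(C)c1ccc(/C=C2\CCCCCC2=O)cc1` differs from it by dimethylamino in place of methyl on an aromatic carbon with dimethylamino in place of methyl on an aromatic carbon. Earlier swaps at this place bear on the change: there was a 4.3-fold lower number from compound 1 to compound 2 (0.63 log units; beyond the scatter) and also an at least 7.3-fold higher number from compound 2 to compound 3 (0.86 log units; beyond the scatter) while the swap from fluoro gave an at least 1.7-fold higher number from compound 1 to compound 3 (0.23 log units; that floor lies within the scatter) in the same read-out. Swaps at this place have thus shifted the number by modest amounts, so a modest move toward stronger inhibition is expected, as an at least 2.7-fold lower number from compound 3 to compound 4 (0.44 log units; beyond the scatter) in this assay for this estimate. For compound 4 the estimated value is 180000 nM with an expected range from 50000 nM to 500000 nM overall.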

Compound 4, half-maximal inhibitory concentration: 79100 nM
For compound 4 the middle estimate is 2.3-fold (0.36 log units) above the measured one; the range from low to high includes it.
By their numbers in this assay, from the lowest: compounds 2 and 4 (each within the scatter of the next); then compound 1. At a limit, above all of these: compound 3.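

In this assay, dimethylamino in place of methyl brings a clear gain, with an at least 6.3-fold lower number from compound 3 to compound 4 (0.80 log units; beyond the scatter). It also separates from fluoro, with a 3.7-fold lower number from compound 1 to compound 4 (0.57 log units; beyond the scatter), but not from bromo, with a 1.2-fold higher number from compound 2 to compound 4 (0.06 log units; within the scatter), so two groups with quite different atoms sit level at this position. The step from methyl is only a floor: the limit of > 500000 nM in this assay, at which 1 of the 4 values shown sits.

As far as these compounds go, whether a primary amine, a methoxy group or a carboxylic acid at this position would reach the level of compound 2 and compound 4 stays open.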